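Thiopyrimidinol series: cytotoxicity notes before compound 4

This account rests on a few compounds, and the source may have more. Where it says the series, first, only, none or still open, it means among the compounds named here.

Measured compounds:
compound 1 `CCC(c1ccccc1)c1cc(O)nc(SC(C)C)n1`: > 200000 nM in a functional assay on MT4 cells (Homo sapiens) for cytotoxicity; on this read-out higher numbers stand for lower toxicity in this test and lower numbers for higher toxicity in this test (a limit of the assay)
compound 2 `CCC(C)Sc1nc(O)cc(C(CC)c2ccccc2)n1`: > 200000 nM in this assay (a limit of the assay)
compound 3 `CC(c1cc(O)nc(SC2CCCC2)n1)c1cccc2ccccc12`: 93000 nM in this assay

Compound 1 and compound 2 share a core and differ by methyl in place of hydrogen on a saturated chain carbon, two bonds along the chain from a sulfur. In this assay compound 1 gives > 200000 nM, which is a limit of the assay and not a number. In this assay compound 2 gives > 200000 nM, again a limit. The step between them is therefore a step that the two limits leave unreadable from compound 1 to compound 2; the reason the step cannot be read is the limit of > 200000 nM in this assay, at which 2 of the 3 values shown sit.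

Compound 3 carries a different core; the difference between the core of compound 3 and the core of compound 1 is not broken down here. In this assay, for the measured compounds named here, compound 3 gives 93000 nM, the only plain number in the set so far.

Compound 4 `CCC(c1cc(O)nc(SC2CCCC2)n1)c1cccc2ccccc12` is not yet measured. It differs from compound 3 by methyl in place of hydrogen on a saturated chain carbon, two bonds along the chain from two aromatic carbons. Going by the values given here, this is the same kind of change as the one from compound 1 to compound 2, not the same change: there the methyl enters two bonds along the chain from a sulfur, here two bonds along the chain from two aromatic carbons. Among the compounds with values here, the only comparable step is unreadable, so the expectation for compound 4 rests on compound 3 and its value 93000 nM, with a step from compound 3 to compound 4 expected at a 1.2-fold higher number from compound 3 to compound 4 (0.07 log units; within the scatter). Compound 4 is thus estimated at 110000 nM in this assay, with a range expected from 45000 nM to 200000 nM.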

Compound 4, half-maximal cytotoxic concentration: > 200000 nM
Compound 4: only a limit was reported; the forecaster's own chance of this, stated with the estimate: 30%; middle value at least 1.8-fold (0.25 log units) from the limit.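

In this assay compound 4 gives > 200000 nM, a limit of the assay and not a number. On the core of compound 3, methyl in place of hydrogen on a saturated chain carbon, two bonds along the chain from two aromatic carbons, comes with an at least 2.1-fold higher number from compound 3 to compound 4 (0.33 log units; beyond the scatter), so this one pair shows lower toxicity in this test with the added methyl, though the true size of the step remains unread. It does not show that the change carries from one core to another, since the same kind of change on the core of compound 1 enters at a different place, two bonds along the chain from a sulfur, and the step from compound 1 to compound 2 cannot be read, because both compounds rest on the same limit: the limit of > 200000 nM in this assay, at which 3 of the 4 values shown sit.

The compounds shown leave open how the core of compound 3 responds when this chain carbon carries a propyl chain, an amine or a carboxylic acid in place of the methyl or ethyl seen so far. They also leave open any readable effect of a chain change on the core of compound 1, where neither compound 1 nor compound 2 gives a plain number.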